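Swapping an Amide for a Sulfone on a Diaryl Alkyne

The source may report more compounds than this note shows. Statements on the series, on what has been measured and on what is new or still open speak of the compounds shown alone.

Measured compounds:
compound 1, `CN(C)C(=O)c1cccc(C#Cc2cc(Cl)ccc2OCC(=O)O)c1`, 52 nM
compound 2, `O=C(O)COc1ccc(Cl)cc1C#Cc1ccccc1C(F)(F)F`, 24 nM
compound 3, `O=C(O)COc1ccc(Cl)cc1C#Cc1ccc(CO)cc1F`, 28 nM

All three were tested in an assay on CHO cells for displacement of a labelled ligand from prostaglandin D2 receptor 2 (Homo sapiens), read by scintillation counting; a lower number here means a stronger inhibitor, a higher number a weaker inhibitor. Compound 1 gives the highest number of the three. Its gap to compound 2 lies beyond the usual scatter, so compound 2 is the stronger binder of that pair; its gap to compound 3 stays within the scatter, so those two cannot be told apart on these numbers alone.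

Compound 4, `CCCS(=O)(=O)c1cccc(C#Cc2cc(Cl)ccc2OCC(=O)O)c1`, has not yet been measured. It differs from compound 1 in one place: propylsulfonyl in place of dimethylcarbamoyl on an aromatic carbon. The shared core of compound 1, with its acid-bearing side chain and the alkyne linker, is kept unchanged.

Among the measured compounds shown here, no measured pair in this set shows what such an exchange does, so the expectation rests only on the spread of the three values. Compound 4 is expected to stay near compound 1, with a step that may fall within the scatter and, if anything, lean toward a lower number. The step expected from compound 1 to compound 4 is a 1.3-fold lower number from compound 1 to compound 4 (0.11 log units; within the scatter). Compound 4 is estimated at 40 nM, between 15 nM and 130 nM.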

Compound 4, inhibition constant: 9 nM
For compound 4 the middle estimate is 4.4-fold (0.65 log units) above the measured one, and the stated range ends above it.
By their numbers in this assay, from the lowest: compound 4; then compounds 2, 3 and 1 (each within the scatter of the next, the first and the last beyond it).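

In this assay, replacing dimethylcarbamoyl with propylsulfonyl on this aromatic carbon, meta to a large group, gives a 5.8-fold lower number from compound 1 to compound 4 (0.76 log units; beyond the scatter), so what this position carries clearly affects the number. The earlier compounds shown here could not show this, as no two of them differed in one place only; here the shared core stays the same, which ties the difference to this single exchange. The exchange alters several things at once, since the entering group has one more heavy atom, carries sulfur and a second oxygen but no nitrogen, and has two hydrogen-bond acceptors instead of one, and no measurement here says which of these changes matters.

The compounds shown leave open whether the sulfonyl unit or its propyl chain accounts for the step, a question that methylsulfonyl or butylsulfonyl at the same place would help to answer. They also leave open whether a propyl chain joined through a carbonyl, as in butanoyl, would behave like propylsulfonyl or like dimethylcarbamoyl.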